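The compounds below may be only part of what the source reports. "The series", "measured", "known", "first", "only" and "open" are said of these compounds alone.

In a functional assay on Hep 3B2 cells (Homo sapiens) for antiproliferative activity, read by sulforhodamine B assay, with a stated time of 48 h (on this read-out lower numbers stand for stronger inhibition of growth and higher numbers for weaker inhibition of growth), two compounds sharing one core have been measured so far. Compound 1 `CC(C)CCc1c(OCCCCCCCC(=O)NO)ccc2ccc(=O)oc12` gives 3580 nM, and compound 2 `CC(C)CCc1c(OCCCCC(=O)NO)ccc2ccc(=O)oc12` gives 1310 nM, the lower of the two numbers. Compound 3 `CC(C)CCc1c(OCCCCCCC(=O)NO)ccc2ccc(=O)oc12` differs from compound 2 in one place: 2-(hydroxycarbamoyl)ethyl in place of hydroxycarbamoyl on a saturated chain carbon, four bonds along the chain from an oxygen on an aromatic ring. Here 2-(hydroxycarbamoyl)ethyl stands in place of hydroxycarbamoyl on a saturated chain carbon, four bonds along the chain from an oxygen on an aromatic ring. Among the compounds with values here, one measured step bears on this change. Putting hydroxycarbamoyl in place of 3-(hydroxycarbamoyl)propyl gave a 2.7-fold lower number from compound 1 to compound 2 (0.44 log units; beyond the scatter), a modest step beyond the scatter. The chain of compound 3 is longer than that of compound 2 but shorter than that of compound 1, so a rise of somewhat smaller size is expected, although two values cannot show whether the trend is smooth. The expected step is a 1.7-fold higher number from compound 2 to compound 3 (0.23 log units; within the scatter). For compound 3 the estimated value is 2200 nM, with an expected range of 900 nM to 5000 nM.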

Compound 3, concentration for 50% growth inhibition: 750 nM
Beside the measured number, compound 3's estimate is 2.9-fold (0.47 log units) above it; the whole stated range lies above it.
By their numbers in this assay, from the lowest: compounds 3 and 2 (each within the scatter of the next); then compound 1.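

Chain length does not raise the number steadily, as the earlier pair might have suggested: the step is a 1.7-fold lower number from compound 2 to compound 3 (0.24 log units; within the scatter), so these two chains cannot be told apart in this measurement. The clear difference appears only with the longest chain, since shortening it gives a 4.8-fold lower number from compound 1 to compound 3 (0.68 log units; beyond the scatter), and compound 1 alone stands apart from the other two. No available evidence explains why the number changes at this point in the chain.

Three chain lengths cannot show where the range of similar values begins or how the numbers continue beyond it, so a chain shorter than that of compound 2 or longer than that of compound 1 remains an open case. Also open, going by these compounds, is how a carboxylic acid at the chain end, in place of hydroxycarbamoyl, would compare.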